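Two Close Values and a Carbamoyl Swap

This account rests on a few compounds, and the source may have more. Where it says the series, first, only, none or still open, it means among the compounds named here.

Measured in a functional assay on NCI-H460 cells (Homo sapiens) for cytotoxicity, read by MTT assay, with a stated time of 3 days; on this read-out lower numbers stand for stronger inhibition and higher numbers for weaker inhibition:
Compound 1 `CNc1nc(SCc2nc3ccccc3[nH]2)nc(-c2ccccc2)c1C#N`: 3.2 nM
Compound 2 `N#Cc1c(NNC(N)=S)nc(SCc2nc3ccccc3[nH]2)nc1-c1ccccc1`: 3.37 nM

The two measured compounds cannot be told apart, with compound 2 at 3.37 nM. For the measured compounds named here, the only measured step, a 1.1-fold higher number from compound 1 to compound 2 (0.02 log units; within the scatter), lies within the scatter. In compound 3 `N#Cc1c(NC(N)=O)nc(SCc2nc3ccccc3[nH]2)nc1-c1ccccc1`, carbamoyl enters on the same nitrogen, and the change is a group of 3 heavy atoms (1 carbon, 1 nitrogen, 1 oxygen; no ring) in place of a group of 4 heavy atoms (1 carbon, 2 nitrogen, 1 sulfur; no ring), on a nitrogen on an aromatic ring. That one step changed the group at this nitrogen and left this assay unmoved beyond the scatter, so no step beyond the scatter is expected here, in either direction. The estimated change is a 1.0-fold higher number from compound 2 to compound 3 (0.02 log units; within the scatter). For compound 3 the expected value is 3.5 nM, with an estimated range from 1.3 nM to 10 nM.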

Compound 3, half-maximal inhibitory concentration: 14.7 nM
For compound 3 the middle estimate is 4.2-fold (0.62 log units) below the measured one; measured number above the stated range.
By their numbers in this assay, from the lowest: compounds 1 and 2 (each within the scatter of the next); then compound 3.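

In this assay this nitrogen on an aromatic ring proves sensitive to what it carries: carbamoyl gives a 4.4-fold higher number from compound 2 to compound 3 (0.64 log units; beyond the scatter) and, in place of methyl, a 4.6-fold higher number from compound 1 to compound 3 (0.66 log units; beyond the scatter). The two earlier compounds showed no step beyond the scatter, so the group on this nitrogen is now seen to matter, though the steps are modest. No evidence on the cause of these steps is available. Still open, going by these compounds, is how an unsubstituted amine or an acetyl group on this nitrogen would read in this assay.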